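The compounds below may be only part of what the source reports. "The series", "measured", "known", "first", "only" and "open" are said of these compounds alone.

Going by the values given here, in a functional assay on MIA PaCa-2 cells (Homo sapiens) for inhibition, read by MTT assay, with a stated time of 48 h, tested at 10 uM (a higher number here means more inhibition of growth at the concentration tested, a lower number less inhibition of growth), compound 1 `Cc1oc2c([C@H]3CCN(C)C[C@H]3O)c(O)cc(O)c2c(=O)c1C(O)c1ccc(F)c(Br)c1` gives 9% and compound 2 `CCOc1ccc(Br)c(C(O)c2c(C)oc3c([C@H]4CCN(C)C[C@H]4O)c(O)cc(O)c3c2=O)c1` gives 4%, so compound 2 stands level with the only other compound measured. Compound 3 `Cc1oc2c([C@H]3CCN(C)C[C@H]3O)c(O)cc(O)c2c(=O)c1C(O)c1cccc(Cl)c1Cl` differs from it by one change: 2,3-dichlorophenyl in place of 2-bromo-5-ethoxyphenyl on a saturated chain carbon bound to an aromatic carbon and an oxygen on a saturated carbon. This puts 2,3-dichlorophenyl in place of 2-bromo-5-ethoxyphenyl on a saturated chain carbon bound to an aromatic carbon and an oxygen on a saturated carbon. Among the compounds with values here, the one measured step at this place, a number 5 percentage points lower from compound 1 to compound 2 (within the scatter), stayed within the scatter, so no step beyond the scatter is expected in this assay. The expected step is a number 3 percentage points higher from compound 2 to compound 3 (within the scatter). For compound 3 the estimate is 7%, with a range of 0% to 18%.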

Compound 3, percent growth inhibition at one concentration: 2%
Beside the measured number, compound 3's estimate is 5 percentage points above it, within the range that was stated.
By their numbers in this assay, from the lowest: compounds 3, 2 and 1 (each within the scatter of the next).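

In this assay, 2,3-dichlorophenyl at this place gives a number 2 percentage points lower from compound 2 to compound 3 (within the scatter), and a number 7 percentage points lower from compound 1 to compound 3 (within the scatter). The three substituted phenyl groups on the saturated chain carbon therefore read alike, so this third halogen pattern adds no separation among them. No available finding bears on why the numbers stay this close.

As far as these compounds go, all three groups are phenyl rings carrying halogen, so it remains open whether an amine or a carboxylic acid on that ring would shift growth inhibition beyond the scatter.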